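Benzyl in place of methyl on the shared core

A few compounds are considered here, and "the series" means these few. Any claim that something is new, unique, unknown or untested is made for them only; others in the source may bear on it.

Measured so far:
compound 1 `Cn1cnc2c(Sc3ccccc3)ncnc21` gives 8%
compound 2 `Cn1cnc2c(Sc3ccc(F)cc3)ncnc21` gives 5%

Both numbers come from an assay on isolated protein for inhibition of Ca2+/calmodulin-dependent protein kinase II (CaM kinase II) (Rattus norvegicus), tested at 30 uM; a lower number here means less inhibition, a higher number more inhibition at the concentration tested (going by the name of the read-out). Among the measured compounds shown here, the one measured step, a number 3 percentage points lower from compound 1 to compound 2 (within the scatter), lies within the scatter, so compound 1 and compound 2 cannot be told apart on this read-out; compound 1 is simply the reference point for the next change. Compound 3 `c1ccc(Cn2cnc3c(Sc4ccccc4)ncnc32)cc1` differs from compound 1 by phenyl in place of hydrogen on a saturated chain carbon bound to an aromatic nitrogen. For the measured compounds named here, no measured step touches this part of the core; the step from compound 1 to compound 2 concerns another place and says nothing here. With nothing to go on beyond the two small numbers, the expected step of a number 4 percentage points higher from compound 1 to compound 3 (within the scatter) is none beyond the scatter. For compound 3 the estimate in this assay is 12%, ranging from 0% to 35%.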

Compound 3, a percentage reported as inhibition, at one concentration (the size of the read-out at that concentration, not a potency): 3%
Compound 3: middle estimate off by 9 percentage points, on the high side, and the stated range covers the measured number.
By their numbers in this assay, from the lowest: compounds 3, 2 and 1 (each within the scatter of the next).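

On the saturated chain carbon bound to an aromatic nitrogen, phenyl in place of hydrogen gives a number 5 percentage points lower from compound 1 to compound 3 (within the scatter) in this assay. Methyl to benzyl therefore leaves compound 1 and compound 3 indistinguishable on this read-out, and this is the first measured step at this part of the core. Nothing on hand bears on the reason for this result.

Open, as far as these compounds go, is whether an amine or a carboxylic acid at this place, or a longer chain such as phenethyl in place of benzyl, would give a step beyond the scatter in this assay.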